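The source may hold more compounds than are shown below. What is called first, only, known or untested is meant among the compounds shown, and "the series" means these compounds.

Measured compounds:
compound 1 `O=C1[C@@H](NS(=O)(=O)c2cc3ccc(Cl)nc3s2)CCN1Cc1cc2[nH]cccc-2n1`, 23%
compound 2 `O=C1[C@@H](NS(=O)(=O)c2cc3ccc(Cl)nc3s2)CCN1Cc1cc2cc[nH]cc-2n1`, 50%
compound 3 `O=C1[C@@H](NS(=O)(=O)c2cc3ccnc(Cl)c3s2)CCN1CCNc1ccncc1`, 23%

In an assay on isolated protein for inhibition of coagulation factor X (Oryctolagus cuniculus), tested at 1 uM (on this read-out lower numbers stand for less inhibition and higher numbers for more inhibition at the one concentration tested (going by the name of the read-out)), compound 3 stands level with compound 1 at the digits shown, and these two are together the lowest of the three numbers; compound 2 sits higher than compound 3 by the same margin as it sits above compound 1. Compound 4 `O=C1[C@@H](NS(=O)(=O)c2cc3ccnc(Cl)c3s2)CCN1Cc1cc2[nH]cccc-2n1` is not yet measured. It differs from compound 3 in one place: a group of 9 heavy atoms (7 carbon, 2 nitrogen; one five-membered aromatic ring with 1 hetero atom, one six-membered aromatic ring with 1 hetero atom) in place of a group of 8 heavy atoms (6 carbon, 2 nitrogen; one six-membered aromatic ring with 1 hetero atom), on a saturated chain carbon bound to an amide-type nitrogen in a ring. The group that enters is the same one carried by compound 1 on its own core. Among the measured compounds shown here, the only measured step, a number 27 percentage points higher from compound 1 to compound 2 (beyond the scatter), concerns a different exchange, between the two bicyclic groups, and so bears only indirectly on this change. What can be read is that compound 1, with the entering group, and compound 3, with the leaving group, show the same number in this assay. A step of no size beyond the scatter is therefore expected, a number 2 percentage points higher from compound 3 to compound 4 (within the scatter). Compound 4 is estimated at 25%, with a range from 10% to 45%.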

Compound 4, a percentage reported as inhibition, at one concentration (the size of the read-out at that concentration, not a potency): 45%
Compound 4: the middle estimate sits 20 percentage points below what was measured; the range from low to high includes it.
By their numbers in this assay, from the lowest: compounds 1 and 3 (each within the scatter of the next); then compounds 4 and 2 (each within the scatter of the next).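

In this assay, putting the bicyclic group in place of the ((pyridin-4-yl)amino)methyl group, on a saturated chain carbon bound to an amide-type nitrogen in a ring, gives a number 22 percentage points higher from compound 3 to compound 4 (beyond the scatter) on the core of compound 3. The matching numbers of compound 1 and compound 3 therefore did not mean that this exchange would be neutral, and the group on the sulfonyl sulfur also counts, since with the bicyclic group kept, changing it gives a number 22 percentage points higher from compound 1 to compound 4 (beyond the scatter) in the same assay. No evidence on the cause of either step is available here.

The compounds shown leave open whether the sulfonyl group exchange has a similar effect when the bicyclic group of compound 2 is present. They also leave open how a simple amine or a longer chain would behave at this place.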